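From Isopropylcarbonyl to Acetyl on the Amide Cap

This account rests on a few compounds, and the source may have more. Where it says the series, first, only, none or still open, it means among the compounds named here.

Compound 1 `CN(c1ccc2cc(NC(=O)CCc3ccc(C(F)(F)F)cc3)ccc2n1)C1CCCC1` gives 350 nM in a functional assay on HEK293 cells for activation of melanin-concentrating hormone receptor 1 (Rattus norvegicus), read by inositol phosphate accumulation; a lower number here means that less compound is needed, a higher number that more compound is needed for the effect.
Compound 2 `O=C(CCc1ccc(C(F)(F)F)cc1)Nc1ccc2nc(N3CCC(c4ccccc4)C3)ccc2c1` gives 1770 nM in this assay.
Compound 3 `CC(C)C(=O)NC1CCN(c2ccc3cc(NC(=O)CCc4ccc(C(F)(F)F)cc4)ccc3n2)C1` gives 90 nM in this assay.

All three share one core and differ only in the group on the aromatic carbon. Compound 3 stands lowest of the three, with a 3.9-fold lower number from compound 1 to compound 3 (0.59 log units; beyond the scatter) and a 20-fold lower number from compound 2 to compound 3 (1.29 log units; beyond the scatter) both beyond the scatter, so it is the one that needs least material here.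

Compound 4 `CC(=O)NC1CCN(c2ccc3cc(NC(=O)CCc4ccc(C(F)(F)F)cc4)ccc3n2)C1` keeps everything of compound 3 except the acyl group: methyl in place of isopropyl on a carbonyl carbon. Within the data shown here, none of the measured steps alters this carbonyl substituent itself. The nearest comparison, a 20-fold lower number from compound 2 to compound 3 (1.29 log units; beyond the scatter), shows that what sits on the saturated ring carbon matters a great deal, but that step exchanged a phenyl for a whole amide, whereas here only the carbon chain on the carbonyl is trimmed while the amide stays. Without a direct precedent, the change is expected to produce at most a small step, and no direction is firmly indicated. A slight rise in the number is expected as the middle case, a 1.4-fold higher number from compound 3 to compound 4 (0.16 log units; within the scatter). Compound 4 is therefore estimated at 130 nM, with a range from 45 nM to 380 nM.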

Compound 4, half-maximal effective concentration: 440 nM
Estimate against measurement, compound 4: 3.4-fold (0.53 log units) below; measured number above the stated range.
By their numbers in this assay, from the lowest: compound 3; then compounds 1 and 4 (each within the scatter of the next); then compound 2.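

Trimming isopropyl to methyl on this carbonyl carbon, with the amide left in place, gives a 4.9-fold higher number from compound 3 to compound 4 (0.69 log units; beyond the scatter) in this assay, so the carbon group on the carbonyl matters in its own right, which the earlier steps could not show when they exchanged whole groups. The amide with the acetyl cap still holds an advantage over the phenyl group, with a 4.0-fold lower number from compound 2 to compound 4 (0.60 log units; beyond the scatter), but a 1.3-fold higher number from compound 1 to compound 4 (0.10 log units; within the scatter) leaves it with no real difference from the cyclopentyl(methyl)amino group, whereas a 3.9-fold lower number from compound 1 to compound 3 (0.59 log units; beyond the scatter) was beyond the scatter, so the edge of compound 3 over compound 1 depends on the isopropyl cap and not on the pyrrolidine amide alone. No measurement shown gives a reason for this effect of the cap.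

From the compounds shown here alone, with only isopropyl and methyl on this carbonyl, two points cannot show how the number responds to the cap, and it stays open whether a cyclopropyl, a tert-butyl or a longer chain such as n-butyl would bring the number below that of compound 3. Going by these compounds, it is equally open how a cap carrying an amine or a carboxylic acid would behave in this assay, with the rest of compound 3 kept unchanged.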